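Piperazine-to-piperidine swap on the solubilising chain

The compounds below may be only part of what the source reports. "The series", "measured", "known", "first", "only" and "open" are said of these compounds alone.

Two compounds of the series have numbers in a functional assay on MKN-45 cells (Homo sapiens) for cytotoxicity, read by MTT assay, with a stated time of 72 h; on this read-out lower numbers stand for stronger inhibition and higher numbers for weaker inhibition. Compound 1 `COc1cc2c(Oc3ccc(NC(=O)c4nn(-c5ccccc5)c(=O)c5ccccc45)cc3F)ccnc2cc1OCCCN1CCN(C)CC1` gives 620 nM and stands as the higher of the two numbers. Compound 2 `COc1cc2c(Oc3ccc(NC(=O)c4nn(-c5ccc(Br)cc5)c(=O)c5ccccc45)cc3F)ccnc2cc1OCCCN1CCN(C)CC1` gives 350 nM. Going by the values given here, the only step between them, a 1.8-fold lower number from compound 1 to compound 2 (0.25 log units; within the scatter), is within the scatter, so neither compound can be called the stronger.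

Compound 3 `COc1cc2c(Oc3ccc(NC(=O)c4nn(-c5ccccc5)c(=O)c5ccccc45)cc3F)ccnc2cc1OCCCN1CCC(C)CC1` is not yet measured in this assay. It differs from compound 1 by 4-methylpiperidin-1-yl in place of 4-methylpiperazin-1-yl on a saturated chain carbon, three bonds along the chain from an oxygen on an aromatic ring. Among the compounds with values here, no measured step touches this part of the molecule: the one step in hand, from compound 1 to compound 2, changes a group on an aromatic carbon elsewhere and was itself within the scatter. There is therefore no measured basis for expecting a shift in either direction beyond the scatter for compound 3.

The number for compound 3 in this assay is estimated at 700 nM, with a range of 250 nM to 2000 nM. This estimate means a step of a 1.1-fold higher number from compound 1 to compound 3 (0.05 log units; within the scatter), which is expected to be no more than the usual scatter.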

Compound 3, half-maximal inhibitory concentration: 580 nM
The estimate for compound 3 lay 1.2-fold (0.08 log units) above the measured number, and the stated range covers the measured number.
By their numbers in this assay, from the lowest: compounds 2, 3 and 1 (each within the scatter of the next).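

In this assay, going by these compounds alone, the step of a 1.1-fold lower number from compound 1 to compound 3 (0.03 log units; within the scatter) is the first measured change on the solubilising chain. It shows that, on a saturated chain carbon, three bonds along the chain from an oxygen on an aromatic ring, 4-methylpiperidin-1-yl can stand in place of 4-methylpiperazin-1-yl with no difference beyond the scatter, even though the ring goes from 2 hetero atoms to 1 and the group from 2 hydrogen-bond acceptors to 1. No measurement in hand bears on why the two groups read alike in this cell assay.

On these data alone, this rests on a single pair, so it remains open whether the same swap would also stay within the scatter on the core of compound 2, which carries the bromo group. As far as these compounds go, it also remains open how this place on the chain would respond to a morpholin-4-yl group, a dimethylamino group or a carboxylic acid, or to a longer chain than the 3-(4-methylpiperidin-1-yl)propyl of compound 3.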